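Moving the Nitrogen Along a Sulfanyl Chain

The source may hold more compounds than are shown below. What is called first, only, known or untested is meant among the compounds shown, and "the series" means these compounds.

In a functional assay on HT cells (Homo sapiens) for antiproliferative activity, read by fluorescence, with a stated time of 72 h (on this read-out higher numbers stand for weaker inhibition of growth and lower numbers for stronger inhibition of growth), compound 1 `CC(C)c1n[nH]c2c(NCc3ccc(-c4ccccn4)cc3)nc(SCC(N)CN)nc12` gives 480 nM while compound 2 `CC(C)c1n[nH]c2c(NCc3ccc(-c4ccccn4)cc3)nc(SCCO)nc12` gives 48 nM and compound 3 `CNCCSc1nc(NCc2ccc(-c3ccccn3)cc2)c2[nH]nc(C(C)C)c2n1` gives 56 nM as the second highest of the three numbers. Compound 3 sits within the scatter of compound 2 and well beneath compound 1. Compound 4 `CC(C)c1n[nH]c2c(NCc3ccc(-c4ccccn4)cc3)nc(SCCCN)nc12` rearranges the same atoms: aminomethyl in place of methylamino on a saturated chain carbon, two bonds along the chain from a sulfur turns 2-(methylamino)ethyl into 3-aminopropyl. The nearest evidence is the step of a 1.2-fold higher number from compound 2 to compound 3 (0.07 log units; within the scatter) for methylamino in place of hydroxy on this same carbon, so this position has so far tolerated a change. The steps of a 10-fold lower number from compound 1 to compound 2 (1.00 log units; beyond the scatter) and an 8.6-fold lower number from compound 1 to compound 3 (0.93 log units; beyond the scatter) are larger and show that the chain can matter. In these, the 1,2-diaminoethyl chain of compound 1 carries the highest number. That single case supports only a slight upward lean for a chain ending in an unsubstituted amino group. The expected result is a 1.5-fold higher number from compound 3 to compound 4 (0.18 log units; within the scatter) and thus a small rise. Compound 4 is estimated at 85 nM in this assay (expected range 35 nM to 250 nM).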

Compound 4, concentration for 50% growth inhibition: 120 nM
Beside the measured number, compound 4's estimate is 1.4-fold (0.15 log units) below it, within the range that was stated.
By their numbers in this assay, from the lowest: compounds 2 and 3 (each within the scatter of the next); then compound 4; then compound 1.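

In this assay, the rearrangement is not neutral: a 2.1-fold higher number from compound 3 to compound 4 (0.33 log units; beyond the scatter) shows that this carbon, which tolerated methylamino in place of hydroxy, responds when the same atoms are joined differently. The 3-aminopropyl chain also separates from the hydroxy-bearing chain, with a 2.5-fold higher number from compound 2 to compound 4 (0.40 log units; beyond the scatter), while a 4.0-fold lower number from compound 1 to compound 4 (0.60 log units; beyond the scatter) shows that hydrogen in place of amino on a saturated chain carbon bound to two saturated chain carbons lowers the number, so a chain ending in an unsubstituted amino group need not reach the number of compound 1. Nothing in the data gives a reason for these steps.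

The move to 3-aminopropyl changes both the chain length and the substitution on the nitrogen, and these compounds cannot separate the two. From the compounds shown here alone, it remains open how a chain ending in dimethylamino, or a longer chain ending in amino, would fall on this read-out.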